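The source may hold more compounds than are shown below. What is called first, only, known or untested is meant among the compounds shown, and "the series" means these compounds.

Working notes on the series. Compound 1 `CCCCc1sc(-c2ccc(Oc3ccc(Cl)cc3)cc2)nc1-c1ccc(OCC2CCCN(CC)C2)cc1` and compound 2 `CCCCc1sc(-c2ccc(OCCCN(CC)CC)cc2)nc1-c1ccc(Oc2ccc(Cl)cc2)cc1` share a core and differ in the amine-bearing side chain. In an assay on isolated protein for antagonist activity at advanced glycosylation end product-specific receptor (Homo sapiens), read by ELISA, with a stated time of 60 min (on this read-out lower numbers stand for stronger inhibition and higher numbers for weaker inhibition), compound 1 gives 1910 nM, and compound 2 gives 1720 nM; the two numbers lie within the scatter of one another, so no order is read between them. Compound 3 `CCCCc1sc(-c2ccc(OCCCN3CCCCC3)cc2)nc1-c1ccc(Oc2ccc(Cl)cc2)cc1` has not been measured. Its difference from compound 2 is piperidin-1-yl in place of diethylamino on a saturated chain carbon, three bonds along the chain from an oxygen on an aromatic ring. Among the compounds with values here, no comparable step between measured compounds exists here, so the step from compound 2 to compound 3 in this assay is expected to be small, a 1.1-fold lower number from compound 2 to compound 3 (0.06 log units; within the scatter), with no clear direction beyond the scatter. Compound 3 is thus estimated at 1500 nM, with a range from 600 nM to 4000 nM.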

Compound 3, half-maximal inhibitory concentration: 1840 nM
Estimate against measurement, compound 3: 1.2-fold (0.09 log units) below; measured number inside the range.
By their numbers in this assay, from the lowest: compounds 2, 3 and 1 (each within the scatter of the next).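

Piperidin-1-yl in place of diethylamino gives a 1.1-fold higher number from compound 2 to compound 3 (0.03 log units; within the scatter) in this assay. Within the data shown here, this is the first direct step at this position, on a saturated chain carbon, three bonds along the chain from an oxygen on an aromatic ring, and it shows that the ring form and the open form of the amine are not told apart here. No evidence on the result is available.

On these data alone, it remains open whether morpholin-4-yl, dimethylamino or a carboxylic acid at the chain end would move the number beyond the scatter. The same holds for a longer chain carrying piperidin-1-yl.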